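The compounds below may be only part of what the source reports. "The series", "measured", "known", "first", "only" and "open" are said of these compounds alone.

In an ADME assay on microsomes from liver (Homo sapiens) for metabolic stability, with a stated time of 10 min (on this read-out higher numbers stand for a more stable compound and lower numbers for a less stable compound), compound 1 `CC(=O)N1CC[C@H](C(=O)N2CC[C@](c3ccc(C(OCc4c(F)cccc4F)(C(F)(F)F)C(F)(F)F)cc3)(S(=O)(=O)c3ccc(F)cc3)C2)C1` gives 19%, compound 2 `O=C(C1CCOCC1)N1CC[C@](c2ccc(C(OCc3c(F)cccc3F)(C(F)(F)F)C(F)(F)F)cc2)(S(=O)(=O)c2ccc(F)cc2)C1` gives 11% and compound 3 `O=C(N1CCOCC1)N1CC[C@](c2ccc(C(OCc3c(F)cccc3F)(C(F)(F)F)C(F)(F)F)cc2)(S(=O)(=O)c2ccc(F)cc2)C1` gives 3%. Compound 3 is thus separated clearly from compound 1 only. Compound 4 `O=C(O)C1CCN(C(=O)N2CC[C@](c3ccc(C(OCc4c(F)cccc4F)(C(F)(F)F)C(F)(F)F)cc3)(S(=O)(=O)c3ccc(F)cc3)C2)CC1` changes the group on the same carbonyl carbon: 4-carboxypiperidin-1-yl in place of morpholin-4-yl on a carbonyl carbon. The measured steps at this place bear on it: a number 8 percentage points lower from compound 1 to compound 2 (within the scatter), a number 8 percentage points lower from compound 2 to compound 3 (within the scatter) and a number 16 percentage points lower from compound 1 to compound 3 (beyond the scatter). None of them brings in a carboxylic acid, so they indicate only the likely size of the step. The value of compound 3, 3%, leaves little room downward, so a modest rise is expected. The expected change is a number 17 percentage points higher from compound 3 to compound 4 (beyond the scatter). Compound 4 is estimated at 20%, within a range of 5% to 50%.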

Compound 4, percent of the compound remaining: 72%
Compound 4: middle estimate off by 52 percentage points, on the low side; the whole stated range lies below it.
By their numbers in this assay, from the lowest: compounds 3, 2 and 1 (each within the scatter of the next, the first and the last beyond it); then compound 4.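

In this assay, within the data shown here, the group on this carbonyl carbon turns out to move the read-out much further than the earlier compounds indicated: 4-carboxypiperidin-1-yl gives a number 69 percentage points higher from compound 3 to compound 4 (beyond the scatter), a number 61 percentage points higher from compound 2 to compound 4 (beyond the scatter) and a number 53 percentage points higher from compound 1 to compound 4 (beyond the scatter). Among these compounds, all three steps are large, whereas the earlier steps at this place were modest or within the scatter. No measurement at hand accounts for the rise.

Going by these compounds, it remains open whether the rise belongs to the carboxylic acid itself or needs the piperidin-1-yl ring that carries it. On these data alone, how a methyl ester, a primary amide or a carboxymethyl chain would read at this place also remains open.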